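A few compounds are considered here, and "the series" means these few. Any claim that something is new, unique, unknown or untested is made for them only; others in the source may bear on it.

Three compounds built on the same core, each carrying a different cyclic amine at one end, have been tested in a functional assay on HeLa cells (Homo sapiens) for antiproliferative activity, read by CCK-8 assay, with a stated time of 72 h, tested at 2 uM; a lower number here means a weaker effect, a higher number a stronger effect of the compound at the concentration tested. Compound 1 `Nc1ccccc1NC(=O)c1ccc(CSC(=S)N2CCN(c3cccnc3)CC2)cc1` gives 66.2% in this assay, the highest of the three numbers. Compound 2 `CC1CCCCN1C(=S)SCc1ccc(C(=O)Nc2ccccc2N)cc1` gives 45.5%, which lies below compound 1 by more than the usual scatter of such measurements. Compound 3 `Nc1ccccc1NC(=O)c1ccc(CSC(=S)N2CCc3cc([N+](=O)[O-])ccc32)cc1` gives 32.6%, the number furthest from compound 1, again beyond the scatter. None of these three compounds differs from another in a single place, so no gap among them can be traced to one structural change, and nothing yet shows how a small swap on the ring amine shifts the read-out.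

Compound 4 `Nc1ccccc1NC(=O)c1ccc(CSC(=S)N2CCN(Cc3ccccc3)CC2)cc1` has not been measured in this assay. It differs from compound 1 in one place: benzyl in place of pyridin-3-yl on an amine nitrogen in a ring. Going by the values given here, with no single-change step to lean on, the expectation must rest on how far the other two compounds fall from compound 1 when the amine part is altered more broadly. A moderate downward step is expected, a number 11.2 percentage points lower from compound 1 to compound 4 (beyond the scatter), though a result within the scatter of compound 1 would not surprise. Compound 4 is therefore estimated at 55%, with a likely range from 35% to 75%.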

Compound 4, a percentage reported as inhibition, at one concentration (the size of the read-out at that concentration, not a potency): 20.6%
Compound 4: the middle estimate sits 34.4 percentage points above what was measured; the measured number lies below the stated range.
By their numbers in this assay, from the lowest: compound 4; then compound 3; then compound 2; then compound 1.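

In this assay, this is the first change in one place among the compounds shown, and it gives a number 45.6 percentage points lower from compound 1 to compound 4 (beyond the scatter), so the read-out depends strongly on the group on this amine nitrogen, even though pyridin-3-yl and benzyl each bring one six-membered aromatic ring and no net charge. The swap alters two things at once: the aromatic ring loses its nitrogen, taking the hydrogen-bond acceptor count of the group from 1 to 0, and the group grows from 6 to 7 heavy atoms, all carbon. Nothing available here links the large step to either of these differences or explains it in any other way.

From the compounds shown here alone, it remains open which of the two differences matters, since a phenyl group on this nitrogen would lack the ring nitrogen without the extra carbon, while pyridin-3-ylmethyl would keep the ring nitrogen and add the extra carbon. Going by these compounds, whether the position of that ring nitrogen matters also stays open, a question that pyridin-2-yl and pyridin-4-yl on the same amine nitrogen could answer.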